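Anilino replaces pyrazolylamino on a shared triazolopyrimidine-like scaffold

This account rests on a few compounds, and the source may have more. Where it says the series, first, only, none or still open, it means among the compounds named here.

This account follows three measured compounds and one that awaits measurement. In a physicochemical assay for solubility, read by LC-MS, in phosphate buffer, with a stated time of 24 h, at pH 7.4 (on this read-out higher numbers stand for higher solubility and lower numbers for lower solubility), compound 1 `CN(C)Cc1ccc2c(c1)CN(c1cnc(NCc3c(F)ccc4c3CCO4)n3cnnc13)C2=O` gives 12000 nM, compound 3 `CNC(=O)c1ccc(-c2cnc(NCc3c(F)ccc4c3CCO4)c3cn[nH]c(=O)c23)c(C)n1` gives 19000 nM, and compound 2 `CN(c1ccn(C)n1)c1cnc(NCc2c(F)ccc3c2CCO3)n2cnnc12` gives 130000 nM. Compound 2 therefore stands highest of the three numbers shown, and its distance to both compound 3 and compound 1 lies beyond the usual scatter of repeated measurements, so its place at the top is secure.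

Compound 4 `Fc1ccc2c(c1CNc1ncc(Nc3ccccc3)c3nncn13)CCO2` is the untested partner of compound 2. The two differ in one place: anilino in place of methyl(1-methyl-1H-pyrazol-3-yl)amino on an aromatic carbon. The group that leaves carries the larger share of nitrogen and hydrogen-bond acceptors, while the group that enters is a carbon-only ring with a single donor and acceptor. Going by the values given here, no measured pair in this set shows the same exchange, so the size of the step can only be guessed from the nature of the groups involved.

He expects the step from compound 2 to compound 4 to be downward, at about a 4.3-fold lower number from compound 2 to compound 4 (0.64 log units; beyond the scatter), beyond the scatter, in this assay. For compound 4 the estimated solubility in this assay is 30000 nM, with a plausible range from 8000 nM to 100000 nM.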

Compound 4, solubility: 3000 nM
The estimate for compound 4 lay 10-fold (1.00 log units) above the measured number; measured number below the stated range.
By their numbers in this assay, from the lowest: compound 4; then compounds 1 and 3 (each within the scatter of the next); then compound 2.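

In this assay, going by these compounds alone, the exchange of methyl(1-methyl-1H-pyrazol-3-yl)amino for anilino on this aromatic carbon gives a 43-fold lower number from compound 2 to compound 4 (1.64 log units; beyond the scatter) as the only step that can be read in the set, and it is a large one, so this is the first sign that the group at this position matters on this read-out. The heavy-atom count barely changes, with 8 in the group that leaves and 7 in the group that enters, yet a five-membered aromatic ring with 2 hetero atoms gives way to a six-membered aromatic ring of carbon only, and the methyl on the amino nitrogen goes with it. Nothing shown bears on why the number drops so far.

The single step changes the ring and the methyl on the amino nitrogen together, so the compounds shown leave open how much of the drop goes with each, a question that methyl(phenyl)amino or unmethylated (1-methyl-1H-pyrazol-3-yl)amino could separate. They also leave open how a morpholine or a carboxylic acid would read at this position.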